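A few compounds are considered here, and "the series" means these few. Any claim that something is new, unique, unknown or untested is made for them only; others in the source may bear on it.

Three measured compounds share one core: compound 1 `Fc1cccc(C#Cc2nc3c(s2)CN(C2CCC2)CC3)c1`, compound 2 `Fc1cccc(C#Cc2nc3c(s2)CN(C2CCOC2)CC3)c1` and compound 3 `CCC(=O)N1CCc2nc(C#Cc3ccccc3)sc2C1`. In an assay on HEK293 cells for negative allosteric modulation of metabotropic glutamate receptor 5 (Homo sapiens), read by FLIPR, with a stated time of 1 h (a lower number here means a stronger inhibitor, a higher number a weaker inhibitor), compound 1 gives 200 nM, compound 2 gives 400 nM and compound 3 gives 38 nM, the lowest number of the three. Among the measured compounds shown here, the only step between measured neighbours, a 2.0-fold higher number from compound 1 to compound 2 (0.30 log units; within the scatter), concerns a group on an amine nitrogen in a ring. Compound 4 `Cc1cccc(C(=O)N2CCc3nc(C#Cc4ccccc4)sc3C2)n1` differs from compound 3 at a different place: 6-methylpyridin-2-yl in place of ethyl on a carbonyl carbon. For the measured compounds named here, no measured step touches this carbonyl carbon, so there is no direct guide. Compound 3, with 38 nM, is the only anchor. For compound 4 the estimated step of a 1.2-fold higher number from compound 3 to compound 4 (0.07 log units; within the scatter) is expected to stay within the scatter. Compound 4 is therefore expected to give about 45 nM in this assay, within 10 nM to 200 nM.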

Compound 4, half-maximal inhibitory concentration: > 10000 nM
Compound 4: no number, only a limit; the forecaster's own chance of this, stated with the estimate: 0%; middle value at least 220-fold (2.34 log units) away from the limit.
By their numbers in this assay, from the lowest: compound 3; then compounds 1 and 2 (each within the scatter of the next). At a limit, above all of these: compound 4.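

In this assay, the group on this carbonyl carbon can decide whether any inhibition is seen, which the step on the amine nitrogen did not show: an at least 260-fold higher number from compound 3 to compound 4 (2.42 log units; beyond the scatter). Among the compounds shown here, this step comes from placing 6-methylpyridin-2-yl where ethyl stood, so a change at this one place can outweigh the differences seen among the earlier compounds. Compound 4 has no number, only a limit: the limit of > 10000 nM in this assay, at which 1 of the 4 values shown sits.

As far as these compounds go, only these two groups on the carbonyl carbon can be compared here, so it stays open where between them the loss sets in. A longer chain, a phenyl ring or a pyridin-2-yl without the methyl could show whether size, the ring nitrogen or the methyl matters.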